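The source may report more compounds than this note shows. Statements on the series, on what has been measured and on what is new or still open speak of the compounds shown alone.

In a functional assay on MCF7 cells (Homo sapiens) for antiproliferative activity, read by MTT assay, with a stated time of 24 h (on this read-out lower numbers stand for stronger inhibition and higher numbers for weaker inhibition), two compounds sharing one core have been measured so far. Compound 1 `CCn1c(C(=O)NCCN)ccc1C(CC)(CC)c1ccc(OCS(=O)(=O)c2ccccc2)c(C)c1`, with 2-aminoethyl on an amide-type nitrogen, gives 6470 nM. Compound 2 `CCn1c(C(=O)N[C@@H](CO)CCO)ccc1C(CC)(CC)c1ccc(OCS(=O)(=O)c2ccccc2)c(C)c1`, with 3-hydroxy-1-(hydroxymethyl)propyl at that place, gives 27400 nM, the higher and therefore weaker of the two numbers. Compound 3 `CCn1c(C(=O)NC2(C(=O)O)CC2)ccc1C(CC)(CC)c1ccc(OCS(=O)(=O)c2ccccc2)c(C)c1` changes the same place again: 1-carboxycyclopropyl in place of 3-hydroxy-1-(hydroxymethyl)propyl on an amide-type nitrogen. Within the data shown here, the only measured step that bears on this change is a 4.2-fold higher number from compound 1 to compound 2 (0.63 log units; beyond the scatter), a modest step at the same nitrogen. It shows that the read-out can move with the group at this place. Neither group in that step holds a ring or a carboxy group, however, so it gives no clear direction for 1-carboxycyclopropyl. No step beyond the scatter is therefore expected in this assay. The estimated step is a 1.5-fold lower number from compound 2 to compound 3 (0.18 log units; within the scatter). For compound 3 the estimated value is 18000 nM, with an expected range from 6000 nM to 55000 nM.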

Compound 3, half-maximal inhibitory concentration: 41200 nM
For compound 3 the middle estimate is 2.3-fold (0.36 log units) below the measured one, and the stated range covers the measured number.
By their numbers in this assay, from the lowest: compound 1; then compounds 2 and 3 (each within the scatter of the next).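

In this assay, putting 1-carboxycyclopropyl in place of 3-hydroxy-1-(hydroxymethyl)propyl on the amide-type nitrogen gives a 1.5-fold higher number from compound 2 to compound 3 (0.18 log units; within the scatter), so these two groups of equal heavy-atom count, one with a three-membered ring and one with no ring, cannot be told apart here. Measured against 2-aminoethyl, the same group gives a 6.4-fold higher number from compound 1 to compound 3 (0.80 log units; beyond the scatter), which makes compound 1 the strongest of the three, as both other groups sit beyond the scatter from it. No measurement shown explains why the numbers fall this way. From the compounds shown here alone, it remains open whether a longer chain ending in an amine, or a dimethylamino group at the chain end, would keep or improve on the number of compound 1. An open-chain carboxylic acid and a plain cyclopropyl group would be needed to separate the contribution of the ring from that of the carboxy group.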